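Methyl position on the aniline ring and cytotoxicity

A few compounds are considered here, and "the series" means these few. Any claim that something is new, unique, unknown or untested is made for them only; others in the source may bear on it.

Compound 1 `Cc1ccccc1Nc1nc(C)c(C(=O)/C=C/c2ccc(Cl)cc2)s1` carries a 2-methylphenyl on the nitrogen on an aromatic ring of the shared core. In a functional assay on Bel-7402 cells (Homo sapiens) for cytotoxicity, read by MTT assay (on this read-out higher numbers stand for weaker inhibition and lower numbers for stronger inhibition), compound 1 gives > 25000 nM, which is a limit of the assay and not a number. Compound 2 `Cc1ccc(Nc2nc(C)c(C(=O)/C=C/c3ccc(Cl)cc3)s2)cc1` differs only in bearing a 4-methylphenyl at that nitrogen. In this assay compound 2 gives > 25000 nM, again a limit rather than a number. The step that the two limits leave unreadable from compound 1 to compound 2 therefore cannot be read; both values sit at the limit of > 25000 nM in this assay, at which 2 of the 2 values shown sit. Within the data shown here, compound 2 thus stands at the limit with no number of its own, and the one other value shown is a limit as well.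

Compound 3 `Cc1cccc(Nc2nc(C)c(C(=O)/C=C/c3ccc(Cl)cc3)s2)c1` is the remaining isomer: 3-methylphenyl in place of 4-methylphenyl on a nitrogen on an aromatic ring. Among the measured compounds shown here, the only measured step that bears on this change is the one from compound 1 to compound 2, and its size is not readable, so it gives no direction. With both neighbours at the limit, compound 3 is expected to show no step beyond the scatter, a step that the limit leaves unreadable from compound 2 to compound 3 being the expected change. Compound 3 is estimated at 35000 nM in this assay, within 12000 nM to 100000 nM, and most probably reported again only as a limit.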

Compound 3, half-maximal inhibitory concentration: > 25000 nM
Compound 3: no number, only a limit; the forecaster's own chance of this, stated with the estimate: 80%; the middle value does not contradict the limit.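

Compound 1, compound 2 and compound 3 all give a limit of the assay and not a number in this assay, so no step among them can be read: the limit of > 25000 nM in this assay, at which 3 of the 3 values shown sit.

The compounds shown leave open how strongly any of the three acts on these cells, and whether 2-methylphenyl, 3-methylphenyl and 4-methylphenyl differ at all.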